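The compounds below may be only part of what the source reports. "The series", "measured", "known", "first", "only" and "open" are said of these compounds alone.

Measured compounds:
compound 1, `CNC(=O)c1cc(Oc2ccc(NC(=O)c3cc4cccnc4n(-c4ccc(Br)cc4F)c3=O)cc2)ccn1`, 1950 nM;
compound 2, `CNC(=O)c1cc(Oc2ccc(NC(=O)c3cc4cccnc4n(-c4ccc(F)c(Cl)c4)c3=O)cc2)ccn1`, 1810 nM.

Among the measured compounds shown here, in a functional assay on HT-29 cells (Homo sapiens) for antiproliferative activity, read by MTT assay, with a stated time of 72 h (a lower number here means a stronger inhibitor, a higher number a weaker inhibitor), compound 1 gives 1950 nM, and compound 2 gives 1810 nM; the one measured step, a 1.1-fold lower number from compound 1 to compound 2 (0.03 log units; within the scatter), concerns the group on an aromatic nitrogen, so the two numbers sit together. Compound 3, `CCCNC(=O)c1cc(Oc2ccc(NC(=O)c3cc4cccnc4n(-c4ccc(Br)cc4F)c3=O)cc2)ccn1`, differs from compound 1 by ethyl in place of hydrogen on a saturated chain carbon bound to an amide-type nitrogen. No measured step touches this part of the molecule, so nothing shown bears directly on the change. The expected step is therefore a 1.0-fold higher number from compound 1 to compound 3 (0.01 log units; within the scatter), not beyond the scatter. Compound 3 is estimated at 2000 nM, between 700 nM and 6000 nM.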

Compound 3, half-maximal inhibitory concentration: 2160 nM
For compound 3 the middle estimate is 1.1-fold (0.03 log units) below the measured one; measured number inside the range.
By their numbers in this assay, from the lowest: compounds 2, 1 and 3 (each within the scatter of the next).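

In this assay, the methylcarbamoyl group of compound 1 gives way to the propylcarbamoyl group of compound 3, with a 1.1-fold higher number from compound 1 to compound 3 (0.04 log units; within the scatter), so the two numbers sit together. Among the compounds shown here, this is the only measured step at this part of the molecule, and it shows that adding ethyl here leaves the reading inside the usual scatter. Nothing given here offers a cause for this result.

From the compounds shown here alone, whether a longer chain, a cyclopropyl group or a chain carrying an amine would behave the same way remains open. So does whether propylcarbamoyl gives a similar reading alongside the 3-chloro-4-fluorophenyl group of compound 2.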